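The compounds below may be only part of what the source reports. "The series", "measured", "known", "first", "only" and "open" are said of these compounds alone.

Measured in an ADME assay on HOS cells (Homo sapiens) for cytotoxicity, read by luminescence and ATP content, with a stated time of 48 h; a higher number here means that more compound is tolerated, a lower number that less compound is tolerated:
- compound 1 `CN(C)CCCc1cnc2c(c1)c(N)c(C(=O)NCc1ccc(F)cc1F)c(=O)n2O`: 5000 nM
- compound 2 `Nc1c(C(=O)NCc2ccc(F)cc2F)c(=O)n(O)c2ncc(CCC(=O)O)cc12`: > 250000 nM, a limit of the assay and not a number

Compound 2 stands at the limit of > 250000 nM in this assay, at which 1 of the 2 values shown sits. Compound 3 `CN(C)C(=O)/C=C/c1cnc2c(c1)c(N)c(C(=O)NCc1ccc(F)cc1F)c(=O)n2O` has 2-(dimethylcarbamoyl)ethenyl in place of 2-carboxyethyl on an aromatic carbon. Going by the values given here, one measured step bears on this change: an at least 50-fold higher number from compound 1 to compound 2 (1.69 log units; beyond the scatter). That large step introduced the carboxy group, and compound 3 lacks it, as compound 1 does. Among the compounds with values here, a clear fall in this assay is therefore expected, with a wide margin, since only that single step supports it. The expected change is an at least 8.3-fold lower number from compound 2 to compound 3 (0.92 log units; beyond the scatter). For compound 3 the estimate is 30000 nM, with an expected range of 6000 nM to 150000 nM.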

Compound 3, half-maximal cytotoxic concentration: > 250000 nM
Compound 3 ended at the assay's limit (the forecaster's own chance of this, stated with the estimate: 20%); middle value at least 8.3-fold (0.92 log units) away from the limit.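

In this assay, replacing 3-(dimethylamino)propyl with 2-(dimethylcarbamoyl)ethenyl gives an at least 50-fold higher number from compound 1 to compound 3 (1.69 log units; beyond the scatter), so the carboxy group is not required at this position for the high tolerance seen earlier. Of the three compounds, only compound 1 falls short of the assay's limit. The step between compound 2 and compound 3 cannot be read: the limit of > 250000 nM in this assay, at which 2 of the 3 values shown sit.

Going by these compounds, it remains open whether a primary amine at the end of the chain would lower the number as the dimethylamino group does. On these data alone, a longer or shorter chain carrying that dimethylamino group also remains untested here.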